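Notes on the series ahead of compound 4

The compounds below may be only part of what the source reports. "The series", "measured", "known", "first", "only" and "open" are said of these compounds alone.

Measured so far:
compound 1 `O=S(=O)(Nc1ccc(-c2nc3ccccc3o2)cc1)c1ccc(Cl)c(C(F)(F)F)c1`, an assay on cells for inhibition of HSP60/HSP10 (Homo sapiens), with a stated time of 60 min (a higher number here means a weaker inhibitor, a lower number a stronger inhibitor), 12000 nM
compound 2 `O=S(=O)(Nc1ccc(-c2nc3ccccc3o2)cc1)c1ccccc1Cl`, this assay > 100000 nM, a limit of the assay rather than a number
compound 3 `O=S(=O)(Nc1ccc(-c2nc3ccccc3o2)cc1)c1ccc(Cl)cc1`, this assay 61000 nM

Compound 3 gives the highest of the two numbers in this assay; compound 1 is nearest, and a 5.1-fold higher number from compound 1 to compound 3 (0.71 log units; beyond the scatter). Compound 2 sits at the limit of > 100000 nM in this assay, at which 1 of the 3 values shown sits, so an at least 1.6-fold lower number from compound 2 to compound 3 (0.21 log units; that floor lies within the scatter) tells little.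

Compound 4 `O=[N+]([O-])c1cc(S(=O)(=O)Nc2ccc(-c3nc4ccccc4o3)cc2)ccc1Cl` differs from compound 3 by nitro in place of hydrogen on an aromatic carbon. For the measured compounds named here, the one step that bears on this is the step from compound 1 to compound 3, where hydrogen in place of trifluoromethyl at the same place raised the number by a 5.1-fold higher number from compound 1 to compound 3 (0.71 log units; beyond the scatter). Putting a group back at that place is therefore expected to lower the number, by about a 4.1-fold lower number from compound 3 to compound 4 (0.61 log units; beyond the scatter). Compound 4 is estimated at 15000 nM, between 4000 nM and 60000 nM.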

Compound 4, half-maximal inhibitory concentration: 17000 nM
For compound 4 the middle estimate is 1.1-fold (0.05 log units) below the measured one; the range from low to high includes it.
By their numbers in this assay, from the lowest: compounds 1 and 4 (each within the scatter of the next); then compound 3. At a limit, above all of these: compound 2.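

Nitro in place of hydrogen ortho to a chloro group brings a 3.6-fold lower number from compound 3 to compound 4 (0.55 log units; beyond the scatter) in this assay, so the lowering at this place is no longer tied to trifluoromethyl alone. Nitro in place of trifluoromethyl gives a 1.4-fold higher number from compound 1 to compound 4 (0.15 log units; within the scatter), and the two groups cannot be told apart in this assay. No measured property available here accounts for this.

Open, as far as these compounds go, is whether an amine, a carboxylic acid or a methyl at this place would give the same lowering. Also open, from the compounds shown here alone, is whether nitro gives it without the chloro group.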